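The source may report more compounds than this note shows. Statements on the series, on what has been measured and on what is new or still open speak of the compounds shown alone.

Compounds measured so far in a functional assay for antagonist activity at Alpha-1A adrenergic receptor (Oryctolagus cuniculus); a lower number here means tighter binding, a higher number weaker binding:

- compound 1, `CN(C)C(=O)c1cccnc1NCCCN1CCN(c2ccccc2OC(F)(F)F)CC1`, 3.16 nM
- compound 2, `CSc1ccccc1N1CCN(CCCNc2ncccc2C(=O)N(C)C)CC1`, 0.631 nM
- compound 3, `CCCc1ccccc1N1CCN(CCCNc2ncccc2C(=O)N(C)C)CC1`, 0.2 nM

Compound 3 gives the lowest number of the three in this assay. The step of a 3.2-fold lower number from compound 2 to compound 3 (0.50 log units; beyond the scatter) is beyond the scatter, as is the larger step of a 16-fold lower number from compound 1 to compound 3 (1.20 log units; beyond the scatter); the step of a 5.0-fold lower number from compound 1 to compound 2 (0.70 log units; beyond the scatter) sits between them in size. All three measured steps change the substituent on the aromatic carbon of the phenyl attached to the piperazine.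

Compound 4, `CC(C)c1ccccc1N1CCN(CCCNc2ncccc2C(=O)N(C)C)CC1`, has not been measured. It differs from compound 3 by isopropyl in place of propyl on an aromatic carbon. For the measured compounds named here, no measured step exchanges one three-carbon group for its isomer; the three steps all exchange groups of different composition, so none bears directly on this change. With the same atoms joined differently and a group of the same size kept at the same place, no step beyond the scatter is expected in this assay. The estimate for compound 4 is therefore close to compound 3, with a 1.3-fold higher number from compound 3 to compound 4 (0.10 log units; within the scatter) expected to lie within the scatter.

Compound 4 is estimated at 0.25 nM, range 0.1 nM to 0.63 nM.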

Compound 4, dissociation constant: 0.398 nM
Estimate against measurement, compound 4: 1.6-fold (0.20 log units) below; measured number inside the range.
By their numbers in this assay, from the lowest: compounds 3, 4 and 2 (each within the scatter of the next, the first and the last beyond it); then compound 1.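

In this assay, isopropyl in place of propyl ortho to a large group gives a 2.0-fold higher number from compound 3 to compound 4 (0.30 log units; within the scatter) and so does not separate 2-propylphenyl from 2-isopropylphenyl. The new compound also reads a 1.6-fold lower number from compound 2 to compound 4 (0.20 log units; within the scatter) against the methylsulfanyl compound, whereas the trifluoromethoxy compound gives a 7.9-fold lower number from compound 1 to compound 4 (0.90 log units; beyond the scatter) and thus remains the only one of the four set apart from all the others by steps beyond the scatter. Nothing available on this series explains how these groups rank at this place.

Going by these compounds, whether an amine, a carboxylic acid or a longer chain such as butyl at this place would stay with compounds 2, 3 and 4 or fall with compound 1 remains open. On these data alone, the rest of the shared core is the same in all four, so whether these readings carry over to another core is also open.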